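Replacing Isopropylsulfonyl with Cyano in Three Related Compounds

A few compounds are considered here, and "the series" means these few. Any claim that something is new, unique, unknown or untested is made for them only; others in the source may bear on it.

Measured so far:
- compound 1 `C=CC(=O)Nc1cc(Nc2ncc(Cl)c(Nc3ccccc3S(=O)(=O)C(C)C)n2)c(OC)cc1N1CCC(N2CCN(C)CC2)CC1`: < 0.3 nM
- compound 2 `C=CC(=O)Nc1cc(Nc2ncc(Cl)c(Nc3ccccc3S(=O)(=O)C(C)C)n2)c(OC)cc1N1CCN(C(C)C)CC1`: < 0.3 nM
- compound 3 `C=CC(=O)Nc1cc(Nc2ncc(Cl)c(Nc3ccccc3C#N)n2)c(OC)cc1N1CCN(C(C)C)CC1`: 110 nM

All three were tested in a functional assay on NCI-H3122 cells (Homo sapiens) for inhibition, read by CellTiter-Glo, with a stated time of 72 h; on this read-out lower numbers stand for stronger inhibition of growth and higher numbers for weaker inhibition of growth. For compound 1 the value < 0.3 nM is a limit of the assay, not a number. For compound 2 the value < 0.3 nM is likewise a limit. Compound 3 gives a number, 110 nM.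

Compounds 1 and 2 share most of their structure; the difference between the two cores is not broken down here. Compound 3 differs from compound 2 in one place: cyano in place of isopropylsulfonyl on an aromatic carbon. That single change produced an at least 360-fold higher number from compound 2 to compound 3 (2.56 log units; beyond the scatter), and its true size cannot be pinned down further because of the limit of < 0.3 nM in this assay, at which 2 of the 3 values shown sit.

The unmeasured compound 4 `C=CC(=O)Nc1cc(Nc2ncc(Cl)c(Nc3ccccc3C#N)n2)c(OC)cc1N1CCC(N2CCN(C)CC2)CC1` stands to compound 1 as compound 3 stands to compound 2: cyano in place of isopropylsulfonyl on an aromatic carbon. The place is described in the same words for both pairs, so this is the same change.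

Among the measured compounds shown here, since compound 1 sits at the same limit as compound 2, the step from compound 1 to compound 4 is expected to be an at least 360-fold higher number from compound 1 to compound 4 (2.56 log units; beyond the scatter), resting on an at least 360-fold higher number from compound 2 to compound 3 (2.56 log units; beyond the scatter) as the only measurement of this change. Compound 4 is therefore expected to land near 110 nM in this assay, most likely between 30 nM and 400 nM.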

Compound 4, concentration for 50% growth inhibition: 98 nM
Compound 4: middle estimate off by 1.1-fold (0.05 log units), on the high side; measured number inside the range.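

In this assay, putting cyano in place of isopropylsulfonyl on the core of compound 1 gave an at least 320-fold higher number from compound 1 to compound 4 (2.51 log units; beyond the scatter), so the large weakening of growth inhibition seen on the first core appeared on the second one as well: the same change on two cores in this assay, an at least 360-fold higher number (2.56 log units; beyond the scatter) from compound 2 to compound 3 and an at least 320-fold higher number (2.51 log units; beyond the scatter) from compound 1 to compound 4; the limit leaves it open whether they differ

The value of compound 1, < 0.3 nM, is a limit of the assay and not a number. The change therefore carried over between these two cores in direction and as a large step, but the true size of each step stays unknown, and it cannot be said whether one core responds more strongly than the other, because of this: the limit of < 0.3 nM in this assay, at which 2 of the 4 values shown sit.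

The compounds shown hold only isopropylsulfonyl or cyano at this place, so it remains open whether another group there, such as methylsulfonyl, an amide or a carboxylic acid, would keep the value at the limit or move it towards those of compound 3 and compound 4. Also open, going by these compounds, is whether the change behaves the same way on cores other than those of compound 1 and compound 2, or in any test other than this assay.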